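The compounds below may be only part of what the source reports. "The series", "measured", "known", "first", "only" and "open" are said of these compounds alone.

Working notes on the series. Three measured compounds share the core of compound 1 `CC(C)(N)CCC(=O)N[C@@H]1CCc2ccccc2N(Cc2ccc(-c3ccccc3-c3nn[nH]n3)cc2)C1=O` and differ only in the chain carried on the amide. In a functional assay on cells (Pituitary gland cell) with growth hormone secretagogue receptor type 1 (Rattus norvegicus) as the target (on this read-out lower numbers stand for an effect already at smaller amounts and higher numbers for an effect only at larger amounts of compound), compound 1 gives 3 uM. Compound 2 `CC[C@@H](N)C(=O)N[C@@H]1CCc2ccccc2N(Cc2ccc(-c3ccccc3-c3nn[nH]n3)cc2)C1=O` gives 0.3 uM in this assay, and the step is a 10-fold lower number from compound 1 to compound 2 (1.00 log units; beyond the scatter). Compound 3 `CC(C)(CC(=O)N[C@@H]1CCc2ccccc2N(Cc2ccc(-c3ccccc3-c3nn[nH]n3)cc2)C1=O)NCCN` gives 230 uM in this assay; it stands highest of the three numbers, with a 77-fold higher number from compound 1 to compound 3 (1.88 log units; beyond the scatter) and a 770-fold higher number from compound 2 to compound 3 (2.88 log units; beyond the scatter). Both steps that lead into compound 3 bring in the (2-aminoethyl)amino chain, and both are large in the same direction.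

Compound 4 `CCCNC(C)(C)CC(=O)N[C@@H]1CCc2ccccc2N(Cc2ccc(-c3ccccc3-c3nn[nH]n3)cc2)C1=O` has not been measured in this assay. It differs from compound 3 by methyl in place of amino on a saturated chain carbon, two bonds along the chain from an amine nitrogen; read one bond further out, (2-aminoethyl)amino becomes propylamino. Among the measured compounds shown here, no measured step removes this amino group on its own, so the evidence is indirect: the two large steps into compound 3 came with the whole chain, and the data do not separate the share of the terminal amino from the rest. A partial move back toward the number of compound 1 is expected, not a full one. The estimated step is a 2.9-fold lower number from compound 3 to compound 4 (0.46 log units; beyond the scatter). For compound 4 the expected value in this assay is 80 uM, with a range from 15 uM to 400 uM.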

Compound 4, concentration for half-maximal effect: 50 uM
For compound 4 the middle estimate is 1.6-fold (0.20 log units) above the measured one; measured number inside the range.
By their numbers in this assay, from the lowest: compound 2; then compound 1; then compound 4; then compound 3.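

Among the compounds shown here, with the single change of methyl in place of amino, read one bond further out as (2-aminoethyl)amino to propylamino, this assay gives a 4.6-fold lower number from compound 3 to compound 4 (0.66 log units; beyond the scatter) and so puts a size on the terminal amino group alone, which the earlier steps could show only together with the rest of the chain. That share is modest and leaves most of the gap in place: the propylamino chain still stands clearly on the high side, with a 17-fold higher number from compound 1 to compound 4 (1.22 log units; beyond the scatter) and with a 170-fold higher number from compound 2 to compound 4 (2.22 log units; beyond the scatter) as well, so removing the terminal amino group does not bring the series back to the numbers of the two compounds with the simpler amine chains. Nothing measured on these compounds bears on the reason for any of these steps.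

Left open is what a hydroxyl, a methoxy or a carboxylic acid at the end of the chain would give in place of the methyl of compound 4. Also open, from the compounds shown here alone, is whether an ethylamino or a methylamino group, or a free amine, on the same saturated chain carbon would move the number further toward that of compound 1.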